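The source may hold more compounds than are shown below. What is called first, only, known or untested is meant among the compounds shown, and "the series" means these compounds.

Measured so far in a functional assay on MDA-MB-436 cells (Homo sapiens) for antiproliferative activity, read by MTT assay, with a stated time of 48 h; on this read-out higher numbers stand for weaker inhibition and lower numbers for stronger inhibition:
compound 1 (`CN1CCN(c2ccc(-c3cc4c(N5CCN(C(=O)Nc6cccc(F)c6)CC5)ncnc4s3)cc2)CC1`) gives 18300 nM
compound 2 (`CN1CCN(c2ccc(-c3cc4c(N5CCN(C(=O)Nc6ccc(F)cc6F)CC5)ncnc4s3)cc2)CC1`) gives 20200 nM

Compound 2 at 20200 nM sits level with compound 1 within the scatter. Compound 3 (`CN1CCN(c2ccc(-c3cc4c(N5CCN(C(=O)Nc6ccc(Cl)c(C(F)(F)F)c6)CC5)ncnc4s3)cc2)CC1`) has 4-chloro-3-(trifluoromethyl)phenyl in place of 2,4-difluorophenyl on an amide-type nitrogen. For the measured compounds named here, the only measured exchange on that nitrogen (a 1.1-fold higher number from compound 1 to compound 2 (0.04 log units; within the scatter)) stayed within the scatter, so no step beyond it is expected in this assay, though neither measured compound carries chlorine or trifluoromethyl. The step expected is small (a 1.4-fold lower number from compound 2 to compound 3 (0.16 log units; within the scatter)). For compound 3 the estimated value is 14000 nM (expected range 4500 nM to 35000 nM).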

Compound 3, half-maximal inhibitory concentration: 3500 nM
Estimate against measurement, compound 3: 4.0-fold (0.60 log units) above, and the stated range ends above it.
By their numbers in this assay, from the lowest: compound 3; then compounds 1 and 2 (each within the scatter of the next).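

In this assay the group on the amide-type nitrogen does change the number: 4-chloro-3-(trifluoromethyl)phenyl gives a 5.8-fold lower number from compound 2 to compound 3 (0.76 log units; beyond the scatter) and a 5.2-fold lower number from compound 1 to compound 3 (0.72 log units; beyond the scatter), whereas the exchange between the two fluorophenyl groups stayed within the scatter. Chlorine and trifluoromethyl enter together, so the step cannot be assigned to either one. No measurement at hand bears on the cause of this step.

Still open, from the compounds shown here alone, is whether a phenyl carrying chlorine alone or trifluoromethyl alone would reproduce the step. Also open, going by these compounds, is how a nitrile or methoxy group on that ring would compare.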